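Lengthening a Fluorinated Chain from Compound 1 to Compound 4

The compounds below may be only part of what the source reports. "The series", "measured", "known", "first", "only" and "open" are said of these compounds alone.

Compound 1, `FC(F)(F)C(F)(F)C(F)(F)C(F)(F)C(F)(F)C(F)(F)CCn1cc(COc2ccccc2-c2nc3ccccc3s2)nn1`: 2.72%
Compound 2, `FC(F)(F)c1cccc(-n2cc(COc3ccccc3-c3nc4ccccc4s3)nn2)c1`: 4.02%
Compound 3, `COc1ccc(-c2nc3cc(F)ccc3s2)cc1OC`: 4.15%

These three compounds were tested in a functional assay on COLO 205 cells (Homo sapiens) for activation, read by flow cytometry, with a stated time of 24 h, tested at 8 uM; a higher number here means a stronger effect of the compound at the concentration tested, a lower number a weaker effect. Compound 1 gives 2.72%, the lowest of the three numbers, but compound 2 with 4.02% and compound 3 with 4.15% both lie within the scatter of it, so the three cannot be told apart by this assay; all three are weak at the concentration tested. No pair of these compounds differs in only one place, so no single structural step is available for comparison.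

Compound 4, `FC(F)(F)C(F)(F)C(F)(F)C(F)(F)C(F)(F)C(F)(F)C(F)(F)C(F)(F)CCn1cc(COc2ccccc2-c2nc3ccccc3s2)nn1`, has not yet been measured. It differs from compound 1 as follows: 1,1,2,2,2-pentafluoroethyl in place of fluoro on a saturated chain carbon bound to two fluorine atoms and a saturated chain carbon. The chain is therefore longer, with nothing else changed. Going by the values given here, nothing among the measured compounds shows what a change of this kind does in this assay, and compound 1 itself sits at the low end of a narrow band. The step of a number 0.8 percentage points higher from compound 1 to compound 4 (within the scatter) is expected to be none beyond the scatter. Compound 4 is therefore estimated at 3.5%, with a range from 0% to 10%.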

Compound 4, a percentage reported as activity, at one concentration (the size of the read-out at that concentration, not a potency): 3.3%
Beside the measured number, compound 4's estimate is 0.2 percentage points above it; the measured number falls inside the stated range.
By their numbers in this assay, from the lowest: compounds 1, 4, 2 and 3 (each within the scatter of the next).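

The swap of fluoro for 1,1,2,2,2-pentafluoroethyl on a saturated chain carbon bound to two fluorine atoms and a saturated chain carbon gives a number 0.6 percentage points higher from compound 1 to compound 4 (within the scatter) in this assay. Going by these compounds alone, this is the first comparison here in which only one place differs, and it shows that, at this chain position, the longer fluorinated chain cannot be told apart from the shorter one in this read-out. No other measurement on these compounds bears on this result.

Still open, going by these compounds, is whether a group of another kind at the end of the chain, such as an amine or a carboxylic acid, would give a number clearly apart from those of compound 1 and compound 4. A plain hydrocarbon chain of similar length, carrying no fluorine, would likewise show whether the fluorine atoms matter at all.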